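This account rests on a few compounds, and the source may have more. Where it says the series, first, only, none or still open, it means among the compounds named here.

Measured so far in an assay on Sf9 cells for inhibition of protein deacetylase HDAC6 (Homo sapiens), read by fluorescence, with a stated time of 40 min, tested at 100 nM; on this read-out higher numbers stand for more inhibition at the one concentration tested (going by the name of the read-out) and lower numbers for less inhibition:
compound 1 `Cc1ccc(-c2nc(CNc3ccc(C(=O)NO)cc3)n(-c3ccccc3)n2)o1` gives 60.7%
compound 2 `O=C(NO)c1ccc(NCc2nc(-c3cccs3)nn2-c2ccc(O)cc2)cc1` gives 79.6%

Compound 1 stands lowest of the two numbers; compound 2 sits a good way higher, beyond the usual scatter. The unmeasured compound 3 `O=C(NO)c1ccc(NCc2nc(-c3cccc4cnccc34)nn2-c2ccccc2)cc1` differs from compound 1 in one place: isoquinolin-5-yl in place of 5-methylfuran-2-yl on an aromatic carbon. For the measured compounds named here, no comparable step between measured compounds is known, so the expectation rests on compound 1 alone. The change is expected to bring a step of a number 4.3 percentage points higher from compound 1 to compound 3 (within the scatter), a size that stays within the usual scatter. Compound 3 is therefore expected to give about 65%, within a range from 45% to 85%.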

Compound 3, a percentage reported as inhibition, at one concentration (the size of the read-out at that concentration, not a potency): 40.2%
Estimate against measurement, compound 3: 24.8 percentage points above; the measured number lies below the stated range.
By their numbers in this assay, from the lowest: compound 3; then compound 1; then compound 2.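

In this assay, this carbon of the shared core does not treat all aromatic groups alike: replacing 5-methylfuran-2-yl, with one ring, by isoquinolin-5-yl, with two, gives a number 20.5 percentage points lower from compound 1 to compound 3 (beyond the scatter). For the compounds shown here, the earlier compounds offered no single-place change, so this is the first sign that the group here can matter. Nothing available explains the loss. A single swap leaves open whether the second ring or the ring nitrogen goes with the lower number. A naphthalen-1-yl or cyclopropyl group here would help separate these possibilities.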